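The source may report more compounds than this note shows. Statements on the series, on what has been measured and on what is new or still open speak of the compounds shown alone.

Compound 1 `Cc1ccccc1Nc1nc(Nc2cccnc2)ncc1Cl`: 22900 nM
Compound 2 `Cc1ccccc1Nc1nc(Nc2ccccc2)ncc1Cl`: > 100000 nM
Compound 3 `Cc1ccccc1Nc1nc(NCc2ccccc2)ncc1Cl`: > 100000 nM

All three values come from an ADME assay on L02 cells (Homo sapiens) for inhibition, read by CCK-8 assay, with a stated time of 48 h; on this read-out higher numbers stand for weaker inhibition of growth and lower numbers for stronger inhibition of growth. Compound 2 gives > 100000 nM, which is a limit of the assay and not a number. Compound 3 gives > 100000 nM, which is also a limit. So most of this small set sits at one ceiling: the limit of > 100000 nM in this assay, at which 2 of the 3 values shown sit.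

Compound 4 `Cc1ccccc1Nc1nc(Nc2ccc(N3CCCCC3)cc2)ncc1Cl` keeps the frame of compound 2 and gains piperidin-1-yl in place of hydrogen on an aromatic carbon. Going by the values given here, no measured step adds this group, so the evidence is indirect. Changing the group on the same nitrogen gave an at least 4.3-fold higher number from compound 1 to compound 2 (0.64 log units; beyond the scatter) and an at least 4.3-fold higher number from compound 1 to compound 3 (0.64 log units; beyond the scatter), both beyond the scatter, while a step that the two limits leave unreadable from compound 2 to compound 3 cannot be sized. Compound 1, at 22900 nM, shows that a readable number is possible on this core. A modest move toward a lower number is therefore expected, although compound 4 may also stay at the limit. The expected change is an at least 2.2-fold lower number from compound 2 to compound 4 (0.34 log units; beyond the scatter). For compound 4 the estimated value is 45000 nM, with an expected range of 12000 nM to 150000 nM.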

Compound 4, concentration for 50% growth inhibition: 5690 nM
Compound 4: middle estimate off by 7.9-fold (0.90 log units), on the high side; measured number outside the range, below it.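

In this assay, placing piperidin-1-yl on an aromatic carbon of the phenyl ring, para to a large group, gives an at least 17-fold lower number from compound 2 to compound 4 (1.24 log units; beyond the scatter). Going by these compounds alone, the earlier compounds varied only the group on the nitrogen, so this is the first sign that a substituent on that ring can bring a compound at the ceiling down to a readable number. The true size of the step stays unknown, since the value of compound 2 is a limit and not a number: the limit of > 100000 nM in this assay, at which 2 of the 4 values shown sit.

The compounds shown leave open whether the effect depends on the piperidine ring itself, which morpholine, piperazine or a simple dimethylamino group at the same place could test. They also leave open whether piperidin-1-yl would give a similar step on the pyridin-3-yl ring of compound 1.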